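This account rests on a few compounds, and the source may have more. Where it says the series, first, only, none or still open, it means among the compounds named here.

Compound 2, with the structure `O=c1cc(Nc2ccccc2)c2ccc(OCc3cccc(Cl)c3)cc2o1`, has the lower number of the two compounds measured here: in an assay on isolated protein (strain Sprague-Dawley) for inhibition of Amine oxidase [flavin-containing] A (Rattus norvegicus), read by spectrophotometry, with a stated time of 5 min, tested at 10 uM (on this read-out higher numbers stand for more inhibition at the one concentration tested (going by the name of the read-out) and lower numbers for less inhibition), compound 2 gives 0%. Its nearest neighbour is compound 1, with the structure `CNC(=O)COc1cc(=O)oc2cc(OCc3cccc(Cl)c3)ccc12`, which in this assay gives 11%. Among the measured compounds shown here, the one measured step, a number 11 percentage points lower from compound 1 to compound 2 (beyond the scatter), was modest in size. Compound 3, with the structure `CCOC(=O)c1cc(=O)oc2cc(OCc3cccc(Cl)c3)ccc12`, differs from compound 2 in a single place: ethoxycarbonyl in place of anilino on an aromatic carbon. For the measured compounds named here, only one measured step bears on this change, and it removed a group at the same place of the shared core rather than adding an ethoxycarbonyl, so it offers only a rough guide. Because the step of a number 11 percentage points lower from compound 1 to compound 2 (beyond the scatter) shows that a change at this place moves the number only modestly, the expectation for compound 3 is a small rise at most, giving an estimated 8%, within a range of 0% to 25%. This corresponds to an expected step of a number 8 percentage points higher from compound 2 to compound 3 (within the scatter).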

Compound 3, a percentage reported as inhibition, at one concentration (the size of the read-out at that concentration, not a potency): 4.4%
Compound 3: the middle estimate sits 3.6 percentage points above what was measured; measured number inside the range.
By their numbers in this assay, from the lowest: compounds 2, 3 and 1 (each within the scatter of the next, the first and the last beyond it).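

Exchanging anilino, with its aromatic ring and hydrogen-bond donor, for ethoxycarbonyl, with neither, gives a number 4.4 percentage points higher from compound 2 to compound 3 (within the scatter) in this assay, so this change opposite the ring oxygen cannot be told apart from no change. Ethoxycarbonyl in place of (methylcarbamoyl)methoxy gives a number 6.6 percentage points lower from compound 1 to compound 3 (within the scatter), also too small to read, and the only step among these three compounds that clears the scatter is a number 11 percentage points lower from compound 1 to compound 2 (beyond the scatter). All three groups, with or without a ring, leave inhibition low at this place, and no evidence is available to explain these numbers.

Going by these compounds, whether any group here can raise inhibition well above these low numbers remains open. A small methyl, a free carboxylic acid or a simple amine at the same place could test this.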